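Naphthyl Replaces Hydroxyphenyl on a Cytotoxicity Scaffold

A few compounds are considered here, and "the series" means these few. Any claim that something is new, unique, unknown or untested is made for them only; others in the source may bear on it.

Measured so far:
compound 1, `O=C1N/C(=N/c2csc(-c3ccc(Cl)cc3)c2)S/C1=C\c1ccccc1`, > 50000 nM
compound 2, `O=C1N/C(=N/c2csc(-c3ccc(Cl)cc3)c2)S/C1=C\c1ccc(O)cc1`, > 50000 nM

Both values are limits of a functional assay on MCF7 cells (Homo sapiens) for cytotoxicity, read by MTT assay, with a stated time of 72 h (on this read-out lower numbers stand for stronger inhibition and higher numbers for weaker inhibition), not numbers. Among the measured compounds shown here, the one step, a step that the two limits leave unreadable from compound 1 to compound 2, is therefore unreadable, and the limit of > 50000 nM in this assay, at which 2 of the 2 values shown sit, is all the evidence there is. Compound 3, `O=C1N/C(=N/c2csc(-c3ccc(Cl)cc3)c2)S/C1=C\c1ccc2ccccc2c1`, carries naphthalen-2-yl in place of 4-hydroxyphenyl on a double-bonded chain carbon bound to a double-bonded ring carbon. With no readable step to lean on, the change is expected to give an at least 1.2-fold lower number from compound 2 to compound 3 (0.09 log units; that floor lies within the scatter), and compound 3 is estimated at 40000 nM (range 8000 nM to 150000 nM), most likely again only a limit.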

Compound 3, half-maximal inhibitory concentration: 1200 nM
Beside the measured number, compound 3's estimate is 33-fold (1.52 log units) above it; measured number outside the range, below it.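

Naphthalen-2-yl on the double-bonded chain carbon bound to a double-bonded ring carbon gives an at least 41-fold lower number from compound 2 to compound 3 (1.61 log units; beyond the scatter), and an at least 41-fold lower number from compound 1 to compound 3 (1.61 log units; beyond the scatter). So in this assay, the group at this place can change the read-out, and compound 3 is the first of these compounds with a value that is a number and not a limit. The step from compound 1 to compound 2 cannot be read, and the earlier pair offered only a limit: the limit of > 50000 nM in this assay, at which 2 of the 3 values shown sit.

As far as these compounds go, it remains open whether a different two-ring group, such as quinolin-3-yl, or a larger one, such as biphenyl-4-yl, would give a similar step. From the compounds shown here alone, it is also open whether a hydroxy or an amine on the naphthalen-2-yl would keep it.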